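A chloronitrophenyl swap on the dienone chain

The source may report more compounds than this note shows. Statements on the series, on what has been measured and on what is new or still open speak of the compounds shown alone.

Compound 1, `O=C(/C=C/c1ccc(Oc2ncnc3ccc(Cl)cc23)cc1)/C=C/c1cc([N+](=O)[O-])ccc1Cl`, in a functional assay on MGC-803 cells (Homo sapiens) for inhibition, read by MTT assay, with a stated time of 72 h; on this read-out higher numbers stand for weaker inhibition and lower numbers for stronger inhibition: 2150 nM
Compound 2, `O=C(/C=C/c1ccc(Oc2ncnc3ccc(Cl)cc23)cc1)/C=C/c1c(Cl)cccc1Cl`, in this assay: 6770 nM
Compound 3, `O=C(/C=C/c1ccc(Cl)c([N+](=O)[O-])c1)/C=C/c1ccccc1Oc1ncnc2ccc(Cl)cc12`, in this assay: 5320 nM

Compound 2 sits at the upper end of these numbers, but its distance from compound 3 is within the scatter, so the two cannot be ordered; only compound 1 lies clearly apart, as the step of a 3.1-fold higher number from compound 1 to compound 2 (0.50 log units; beyond the scatter) shows. Compound 4, `O=C(/C=C/c1ccc(Oc2ncnc3ccc(Cl)cc23)cc1)/C=C/c1ccc(Cl)c([N+](=O)[O-])c1`, differs from compound 2 in one place: 4-chloro-3-nitrophenyl in place of 2,6-dichlorophenyl on a double-bonded chain carbon bound to a double-bonded chain carbon. Going by the values given here, the one measured step that bears on this is the move in the other direction, a 3.1-fold higher number from compound 1 to compound 2 (0.50 log units; beyond the scatter), where a chloro-nitro-substituted phenyl was exchanged for the 2,6-dichlorophenyl and the number rose. Among the compounds with values here, compound 3 carries the same 4-chloro-3-nitrophenyl as compound 4, yet its core is attached at a different ring position, and no single-change step links it to compound 2, so its value can only be noted beside that of compound 1. On this basis a modest fall in this assay is expected, roughly reversing what the step from compound 1 to compound 2 did. Compound 4 is therefore estimated at 2700 nM, within a range of 1100 nM to 6500 nM, an expected step of a 2.5-fold lower number from compound 2 to compound 4 (0.40 log units; beyond the scatter).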

Compound 4, half-maximal inhibitory concentration: 7190 nM
For compound 4 the middle estimate is 2.7-fold (0.43 log units) below the measured one; measured number above the stated range.
By their numbers in this assay, from the lowest: compound 1; then compounds 3, 2 and 4 (each within the scatter of the next).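

In this assay the exchange of 2,6-dichlorophenyl for 4-chloro-3-nitrophenyl gave a 1.1-fold higher number from compound 2 to compound 4 (0.03 log units; within the scatter) and so left no readable difference between these two groups at this place on the chain. The exchange of 2-chloro-5-nitrophenyl for 4-chloro-3-nitrophenyl gave a 3.3-fold higher number from compound 1 to compound 4 (0.52 log units; beyond the scatter), which shows that having a chloro and a nitro group on this phenyl ring does not by itself give the lower number of compound 1. Among compounds 1, 2 and 4, only the 2-chloro-5-nitrophenyl group stands apart, and the arrangement of the two groups on the ring matters more here than their presence. No further measurement bears on why this is so.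

The compounds shown leave open whether the chloro or the nitro group of the 2-chloro-5-nitrophenyl carries the difference, as neither is present alone at this place. Going by these compounds, it also remains open whether an amine or a nitrile in place of that nitro group would keep the number of compound 1 or lose it.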